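From benzyl to butyl on the amide

The compounds below may be only part of what the source reports. "The series", "measured", "known", "first", "only" and "open" are said of these compounds alone.

- Compound 1 `COc1cc2c(cc1O)CCC(C(=O)NCc1ccccc1)O2`: 16600 nM
- Compound 2 `COc1cc2c(cc1O)CCC(C(=O)Nc1ccccc1)O2`: 6900 nM
- Compound 3 `COc1cc2c(cc1O)C(=O)CC(C(=O)Nc1ccccc1)O2`: 293000 nM

In a functional assay (brain) for inhibition, with Rattus norvegicus as the target (a lower number here means a stronger inhibitor, a higher number a weaker inhibitor), compound 1 stands in the middle of the three measured compounds, with compound 2 lower and compound 3 higher. Compound 4 `CCCCNC(=O)C1CCc2cc(O)c(OC)cc2O1` keeps the core of compound 1 but carries propyl in place of phenyl on a saturated chain carbon bound to an amide-type nitrogen. Put another way, benzyl becomes butyl. Among the measured compounds shown here, only one measured step bears on this change: a 2.4-fold lower number from compound 1 to compound 2 (0.38 log units; beyond the scatter). That step was modest, and it gives no direction for a group without a ring. Compound 3 has a different core, so it offers no guide. No clear change is therefore expected in this assay. The expected change is a 1.2-fold higher number from compound 1 to compound 4 (0.08 log units; within the scatter), which would lie within the scatter. For compound 4 the estimated value is 20000 nM, with an expected range of 7000 nM to 60000 nM.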

Compound 4, half-maximal inhibitory concentration: 51300 nM
Estimate against measurement, compound 4: 2.6-fold (0.41 log units) below, and the stated range covers the measured number.
By their numbers in this assay, from the lowest: compound 2; then compound 1; then compound 4; then compound 3.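

In this assay, replacing benzyl with butyl on the amide-type nitrogen gives a 3.1-fold higher number from compound 1 to compound 4 (0.49 log units; beyond the scatter), so losing the ring weakens inhibition rather than leaving it unchanged. Replacing phenyl with butyl gives a larger loss, a 7.4-fold higher number from compound 2 to compound 4 (0.87 log units; beyond the scatter), which places the open chain behind both ring-bearing groups on the shared core. No measurement here explains why. From the compounds shown here alone, whether the ring itself matters, or only the shape and length of the group, stays open. A cyclohexyl group or a longer chain such as octyl on that nitrogen would help separate these possibilities.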